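Oxazolidinedione attachment in the EP3 antagonist series

A few compounds are considered here, and "the series" means these few. Any claim that something is new, unique, unknown or untested is made for them only; others in the source may bear on it.

Compound 1 `CC(C)[C@H](C[C@H]1OC(=O)NC1=O)c1ccc(-c2ccc3cccc(F)c3c2)[nH]c1=O` carries a (2,4-dioxo-1,3-oxazolidin-5-yl)methyl group on a saturated chain carbon bound to an aromatic carbon and a saturated chain carbon. In a functional assay on CHO cells for antagonist activity at prostaglandin E2 receptor EP3 subtype (Homo sapiens), read by cAMP accumulation, with a stated time of 30 min (a higher number here means a weaker inhibitor, a lower number a stronger inhibitor), compound 1 gives 15 nM, the lowest of the two numbers measured. Compound 2 `CCC(CC)C(/C=C1\OC(=O)NC1=O)c1ccc(-c2ccc3cccc(F)c3c2)[nH]c1=O` gives 23 nM in this assay, within the scatter of compound 1, so no order between the two is claimed. Compound 3 `CC(C)[C@@H](c1ccc(-c2ccc3cccc(F)c3c2)[nH]c1=O)[C@H]1OC(=O)NC1=O` differs from compound 1 by 2,4-dioxo-1,3-oxazolidin-5-yl in place of (2,4-dioxo-1,3-oxazolidin-5-yl)methyl on a saturated chain carbon bound to an aromatic carbon and a saturated chain carbon. Among the measured compounds shown here, no measured pair shows a change of this kind. A modest weakening, beyond the scatter, is expected: a 3.0-fold higher number from compound 1 to compound 3 (0.48 log units; beyond the scatter). Compound 3 is therefore estimated at 45 nM, with a range from 12 nM to 200 nM.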

Compound 3, half-maximal inhibitory concentration: 92 nM
For compound 3 the middle estimate is 2.0-fold (0.31 log units) below the measured one, and the stated range covers the measured number.
By their numbers in this assay, from the lowest: compounds 1 and 2 (each within the scatter of the next); then compound 3.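

Placing 2,4-dioxo-1,3-oxazolidin-5-yl in place of (2,4-dioxo-1,3-oxazolidin-5-yl)methyl on this saturated chain carbon gives a 6.1-fold higher number from compound 1 to compound 3 (0.79 log units; beyond the scatter) in this assay. The length of the link to the ring therefore matters at this position, and the shorter attachment gives the weaker inhibitor of this pair. Nothing available explains this step.

Open: whether a longer chain, such as a two-carbon link to the same ring, keeps the activity of compound 1, and whether a carboxylic acid can replace the ring here.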